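Chloro for Fluoro on the Urea Aryl Ring

This account rests on a few compounds, and the source may have more. Where it says the series, first, only, none or still open, it means among the compounds named here.

Measured compounds:
- compound 1, `COc1cc(NC(C)CCCNC(=O)Nc2ccc(F)cc2)c2ncccc2c1`: 26000 nM
- compound 2, `COc1cc(NC(C)CCCNC(=O)NNC(=O)Nc2ccc(F)cc2)c2ncccc2c1`: 310 nM
- compound 3, `COc1cc(NC(C)CCCNC(=O)NNC(=O)Nc2ccc(Cl)cc2)c2ncccc2c1`: 180 nM

In a functional assay on MCF7 cells (Homo sapiens) for inhibition, read by MTT assay, with a stated time of 72 h (a higher number here means a weaker inhibitor, a lower number a stronger inhibitor), compound 1 gives 26000 nM, the highest of the three numbers. Its nearest neighbour is compound 2, reached by an 84-fold lower number from compound 1 to compound 2 (1.92 log units; beyond the scatter); the furthest is compound 3, reached by a 140-fold lower number from compound 1 to compound 3 (2.16 log units; beyond the scatter). The unmeasured compound 4, `COc1cc(NC(C)CCCNC(=O)Nc2ccc(Cl)cc2)c2ncccc2c1`, differs from compound 1 by chloro in place of fluoro on an aromatic carbon.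

For the measured compounds named here, one measured step bears on this change: a 1.7-fold lower number from compound 2 to compound 3 (0.24 log units; within the scatter). That step lies within the scatter, so the same swap made on compound 1 is expected to produce no step beyond the scatter in this assay. Compound 4 is therefore expected to stay near compound 1, with a 1.4-fold lower number from compound 1 to compound 4 (0.16 log units; within the scatter). For compound 4 the estimated value is 18000 nM, within a range from 8000 nM to 45000 nM.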

Compound 4, half-maximal inhibitory concentration: 12000 nM
Estimate against measurement, compound 4: 1.5-fold (0.18 log units) above, and the stated range covers the measured number.
By their numbers in this assay, from the lowest: compounds 3 and 2 (each within the scatter of the next); then compound 4; then compound 1.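

In this assay, chloro in place of fluoro on the aromatic carbon now gives a small step on the core of compound 1 as well, a 2.2-fold lower number from compound 1 to compound 4 (0.34 log units; beyond the scatter), which is just beyond the scatter, whereas the earlier pair had shown this swap only on the core of compound 2. The change is of similar size on the two cores: the same change on two cores in this assay, a 1.7-fold lower number (0.24 log units; within the scatter) from compound 2 to compound 3 and a 2.2-fold lower number (0.34 log units; beyond the scatter) from compound 1 to compound 4, 1.3-fold (0.10 log units) apart, within the scatter of two such steps. At this position the halogen swap counts for far less than the rest of the side chain, as the large steps of a 67-fold higher number from compound 3 to compound 4 (1.82 log units; beyond the scatter) and a 39-fold higher number from compound 2 to compound 4 (1.59 log units; beyond the scatter) show.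

The compounds shown leave open how bromo, methyl or trifluoromethyl would behave at this position on either core. They also leave open whether the phenyl ring with hydrogen there would follow the same order.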